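The source may report more compounds than this note shows. Statements on the series, on what has been measured and on what is new or still open speak of the compounds shown alone.

In a functional assay on PC-3 cells (Homo sapiens) for inhibition, with a stated time of 48 h, tested at 50 uM (a higher number here means more inhibition of growth at the concentration tested, a lower number less inhibition of growth), three compounds that share one core and differ in the length of one saturated chain have been measured. Compound 1 `C=C[C@@](C)(/C=C/c1ccc(OC(=O)CC)cc1)CCC=C(C)C` gives 54%, compound 2 `C=C[C@@](C)(/C=C/c1ccc(OC(=O)CCC)cc1)CCC=C(C)C` gives 38%, and compound 3 `C=C[C@@](C)(/C=C/c1ccc(OC(=O)CCCC)cc1)CCC=C(C)C` gives 42%. Compound 3 therefore stands level with one neighbour but not the other: the data show a number 4 percentage points higher from compound 2 to compound 3 (within the scatter), and also a number 12 percentage points lower from compound 1 to compound 3 (beyond the scatter).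

Compound 4 `C=C[C@@](C)(/C=C/c1ccc(OC(=O)CCCCC)cc1)CCC=C(C)C` extends the same chain, and the change is methyl in place of hydrogen on a saturated chain carbon, four bonds along the chain from a carbonyl carbon.

Two measured steps are of this same kind. The first is a number 16 percentage points lower from compound 1 to compound 2 (beyond the scatter), a drop that was not continued by the next one, a number 4 percentage points higher from compound 2 to compound 3 (within the scatter). Since the later extension made no clear difference, no change beyond the scatter is expected here, and the expected result is a number 2 percentage points lower from compound 3 to compound 4 (within the scatter). For compound 4 the estimated value is 40%, with an expected range from 28% to 52%.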

Compound 4, percent growth inhibition at one concentration: 28%
Compound 4: middle estimate off by 12 percentage points, on the high side; the range from low to high includes it.
By their numbers in this assay, from the lowest: compounds 4, 2 and 3 (each within the scatter of the next, the first and the last beyond it); then compound 1.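

Placing methyl on a saturated chain carbon, four bonds along the chain from a carbonyl carbon, does register in this assay, with a number 14 percentage points lower from compound 3 to compound 4 (beyond the scatter), so the unclear step from compound 2 to compound 3 did not mark the end of any effect of chain length. Across the compounds shown, the propyl change gives a number 26 percentage points lower from compound 1 to compound 4 (beyond the scatter), whereas the ethyl change gives a number 10 percentage points lower from compound 2 to compound 4 (within the scatter), so the series is not a steady decline, and compound 3 goes against one. The methyl change has a similar size in two of its three occurrences, with the step to compound 3 as the exception: the same change on two cores in this assay, a number 16 percentage points lower (beyond the scatter) from compound 1 to compound 2 and a number 14 percentage points lower (beyond the scatter) from compound 3 to compound 4, 2 percentage points apart, within the scatter of two such steps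

The compounds shown leave open whether a longer chain would lower the number further. They also leave open how a chain ending in an amine or a carboxylic acid would compare at this place.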